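This account rests on a few compounds, and the source may have more. Where it says the series, first, only, none or still open, it means among the compounds named here.

Compound 3 `CCCn1c(=O)[nH]c2nc(-c3ccc(S(=O)(=O)N4CCN(c5ccc(F)cc5)CC4)cc3)[nH]c2c1=O` stands in an assay on CHO cells for displacement of a labelled ligand from adenosine receptor A3 (Homo sapiens), read by scintillation counting, with a stated time of 45 min, in the presence of a further agent that is not named here (on this read-out higher numbers stand for weaker inhibition and lower numbers for stronger inhibition), only at a limit of the assay, > 1000 nM. Compound 1 `CCCn1c(=O)[nH]c2nc(-c3ccc(S(=O)(=O)N4CCN(c5cccc(Br)c5)CC4)cc3)[nH]c2c1=O` likewise gives only the limit > 1000 nM in this assay. Compound 2 `CCCn1c(=O)[nH]c2nc(-c3ccc(S(=O)(=O)N4CCN(Cc5ccc(Br)cc5)CC4)cc3)[nH]c2c1=O` also gives only the limit > 1000 nM in this assay. The steps among them, a step that the two limits leave unreadable from compound 1 to compound 2, a step that the two limits leave unreadable from compound 1 to compound 3 and a step that the two limits leave unreadable from compound 2 to compound 3, cannot be sized because of the limit of > 1000 nM in this assay, at which 3 of the 3 values shown sit. The change to compound 4 `CCCn1c(=O)[nH]c2nc(-c3ccc(S(=O)(=O)N4CCN(c5cccc(Cl)c5)CC4)cc3)[nH]c2c1=O` is 3-chlorophenyl in place of 4-fluorophenyl on an amine nitrogen in a ring. Within the data shown here, none of the measured steps gives a readable size or direction for this change, so no step beyond the scatter can be expected, and compound 4 is expected to remain near the limit, with an estimated step that the limit leaves unreadable from compound 3 to compound 4. Compound 4 is estimated at 2000 nM, between 400 nM and 10000 nM.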

Compound 4, inhibition constant: 53.5 nM
The estimate for compound 4 lay 37-fold (1.57 log units) above the measured number; the measured number lies below the stated range.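

In this assay, the group on the amine nitrogen in a ring now gives a readable result: 3-chlorophenyl gives an at least 18-fold lower number from compound 3 to compound 4 (1.27 log units; beyond the scatter) and an at least 18-fold lower number from compound 2 to compound 4 (1.27 log units; beyond the scatter). Chloro in place of bromo on an aromatic carbon alone gives an at least 18-fold lower number from compound 1 to compound 4 (1.27 log units; beyond the scatter), so at this place the outcome turns on the halogen and not only on the ring that carries it. The steps among compounds 1, 2 and 3 remain unreadable: the limit of > 1000 nM in this assay, at which 3 of the 4 values shown sit.

The compounds shown leave open whether a methyl group or an iodo group in place of chloro would keep the number of compound 4.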